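Removing the ring nitrogen methyl: compound 2 to compound 3

The source may report more compounds than this note shows. Statements on the series, on what has been measured and on what is new or still open speak of the compounds shown alone.

Measured compounds:
compound 1, `Cc1ccc2[nH]c(C(=O)N[C@H]3CN(S(=O)(=O)c4ccccc4)C[C@@H]3C(=O)N[C@@H]3CCCN(C)C3)cc2c1`: 23 uL/min
compound 2, `Cc1ccc2[nH]c(C(=O)N[C@H]3CCN(S(=O)(=O)c4ccccc4Cl)C[C@@H]3C(=O)N[C@H]3CCCN(C)C3)cc2c1`: 66 uL/min

For the measured compounds named here, in an ADME assay on cells (Hepatocyte, Rattus norvegicus) for metabolic stability (on this read-out lower numbers stand for slow clearance and higher numbers for fast clearance), compound 2 gives 66 uL/min, the higher of the two numbers measured so far. Compound 1 gives 23 uL/min in this assay, a value lower than that of compound 2 by more than the scatter, but the two compounds differ in several places at once, so no single step can be read from them.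

Compound 3, `Cc1ccc2[nH]c(C(=O)N[C@H]3CCN(S(=O)(=O)c4ccccc4Cl)C[C@@H]3C(=O)N[C@H]3CCCNC3)cc2c1`, has not yet been measured. It differs from compound 2 in one place: hydrogen in place of methyl on an amine nitrogen in a ring.

Going by the values given here, no measured pair shows this kind of change, so the data give no direct guide to its size. On that basis the step from compound 2 to compound 3 in this assay is expected to stay within the scatter, leaning slightly toward slower clearance: a 1.5-fold lower number from compound 2 to compound 3 (0.17 log units; within the scatter). Compound 3 is therefore estimated at 45 uL/min, with a range from 20 uL/min to 100 uL/min.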

Compound 3, intrinsic clearance in a liver preparation (reported as CLH), per the amount of preparation that the assay uses in the Hepatocyte assay: 7 uL/min
Estimate against measurement, compound 3: 6.4-fold (0.81 log units) above, and the stated range ends above it.
By their numbers in the Hepatocyte assay, from the lowest: compound 3; then compound 1; then compound 2.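

Hydrogen in place of methyl on the amine nitrogen in the ring is the only change here that can be read alone, and it is far from neutral: in the Hepatocyte assay, a 9.4-fold lower number from compound 2 to compound 3 (0.97 log units; beyond the scatter). In a physicochemical assay for lipophilicity, measured as octanol-water partition, at pH 7.4 (a lower number here means a more polar compound, a higher number a more lipophilic compound), compound 2 gives 3.1 and compound 3 gives 1.9. Clearance therefore falls together with lipophilicity at this position, two ring bonds from the ring atom that bears a large group, and the lower clearance may owe something to that shift: the measured distribution coefficient of compound 2, 3.1, and of compound 3, 1.9, a number 1.20 log units lower (beyond the scatter)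

A single step cannot show whether the distribution coefficient or the exposed amine hydrogen matters more. Nor do these compounds show how an ethyl or acetyl group on the same nitrogen would behave in either read-out.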